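Replacing the cyanoguanidine group at the chain end

The source may hold more compounds than are shown below. What is called first, only, known or untested is meant among the compounds shown, and "the series" means these compounds.

Of the compounds shown here, three have been tested in a functional assay on the whole organism (stomach) with Rattus norvegicus as the target; a higher number here means that more compound is needed for the effect, a lower number that less compound is needed. Compound 1 `O=c1ccc(-c2ccccc2)nn1CCCCNC(=S)Nc1cccc2ccccc12` reaches only the limit of the assay, giving > 100 mg/kg. Compound 2 `N#CNC(=N)NCCCn1nc(-c2ccccc2)ccc1=O` likewise returns only a limit, > 100 mg/kg. Compound 3 `C/N=C(/NC#N)NCCCCCn1nc(-c2ccccc2)cc(C)c1=O` also stops at a limit, > 100 mg/kg. Compound 2 therefore stands exactly where every measured value sits: the limit of > 100 mg/kg in this assay, at which 3 of the 3 values shown sit. Within the data shown here, because of the limit of > 100 mg/kg in this assay, at which 3 of the 3 values shown sit, no step between measured compounds can be drawn, and nothing is known about how far any structural change moves this assay.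

Compound 4 `CN(C)/C(=N/CCCn1nc(-c2ccccc2)ccc1=O)NC#N` differs from compound 2 by a group of 8 heavy atoms (4 carbon, 4 nitrogen; no ring) in place of a group of 6 heavy atoms (2 carbon, 4 nitrogen; no ring), on a saturated chain carbon, three bonds along the chain from an aromatic nitrogen. With all its neighbours sitting at the limit, the step expected in this assay is a step that the limit leaves unreadable from compound 2 to compound 4, that is, none beyond the scatter. Compound 4 is accordingly estimated to give around 150 mg/kg, within a range from 60 mg/kg to 400 mg/kg, and it is expected that the assay will most probably again report only a limit rather than a number.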

Compound 4, dose for half-maximal effect: 53 mg/kg
For compound 4 the middle estimate is 2.8-fold (0.45 log units) above the measured one, and the stated range ends above it.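

In this assay compound 4 gives 53 mg/kg, the only number among the compounds shown, so a group on a saturated chain carbon, three bonds along the chain from an aromatic nitrogen, can go with a readable value. Placing the group of 8 heavy atoms, with 1 hydrogen-bond donor, where the group of 6 heavy atoms with 3 hydrogen-bond donors stood gives an at least 1.8-fold lower number from compound 2 to compound 4 (0.27 log units; that floor lies within the scatter). The true size of this step remains unknown because compound 2 sits at a limit: the limit of > 100 mg/kg in this assay, at which 3 of the 4 values shown sit.

As far as these compounds go, whether a urea or a pyrrolidine at the chain end would also give a number remains open. From the compounds shown here alone, compounds 1 and 3 differ from compound 4 in more than one place, so how a longer chain would act with the group of compound 4 also remains open.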